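From 2-hydroxyethoxy to 2,2-dimethoxyethoxy in a small series

The source may hold more compounds than are shown below. What is called first, only, known or untested is meant among the compounds shown, and "the series" means these compounds.

In a functional assay on DU-145 cells (Homo sapiens) for antiproliferative activity, read by MTT assay, with a stated time of 3 days (a lower number here means a stronger inhibitor, a higher number a weaker inhibitor), compound 1 `C=CC(=O)Nc1ccc(-c2cc(=O)c3c(O)cc(OC)c(OC(C)C)c3o2)cc1` gives 14700 nM and compound 2 `COc1cc(O)c2c(=O)cc(-c3ccc(NC(=O)NC4CC4)cc3)oc2c1OC(C)C` gives 15600 nM. Compound 3 `COc1cc(O)c2c(=O)cc(-c3ccc(N4CC(C)NC(C)C4)cc3)oc2c1OCCO` gives 6500 nM, the lowest of the three numbers, and its gaps to the other two lie beyond the scatter.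

Compound 4 `COc1cc(O)c2c(=O)cc(-c3ccc(N4CC(C)NC(C)C4)cc3)oc2c1OCC(OC)OC` has not yet been measured. It differs from compound 3 in one place: dimethoxymethyl in place of hydroxymethyl on a saturated chain carbon bound to an oxygen on an aromatic ring. This puts dimethoxymethyl in place of hydroxymethyl on a saturated chain carbon bound to an oxygen on an aromatic ring, so that 2-hydroxyethoxy becomes 2,2-dimethoxyethoxy.

Going by the values given here, only one single-place step has been measured: a 1.1-fold higher number from compound 1 to compound 2 (0.03 log units; within the scatter). That step lies within the scatter, but it exchanges vinyl for cyclopropylamino on a carbonyl carbon, so it bears on the present change only weakly. Among the compounds with values here, no measured step touches the 2-hydroxyethoxy chain, and the series offers no direct precedent for this change.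

With so little evidence, no step beyond the scatter is expected in this assay, and the estimated step is a 1.2-fold higher number from compound 3 to compound 4 (0.06 log units; within the scatter). The range is kept wide to reflect this lack of precedent. For compound 4 the estimated value is 7500 nM, with an expected range of 3000 nM to 18000 nM.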

Compound 4, half-maximal inhibitory concentration: 23600 nM
For compound 4 the middle estimate is 3.1-fold (0.50 log units) below the measured one; measured number outside the range, above it.
By their numbers in this assay, from the lowest: compound 3; then compounds 1, 2 and 4 (each within the scatter of the next).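

In this assay, the saturated chain on the oxygen on an aromatic ring emerges as a place where the number responds to change: going from 2-hydroxyethoxy to 2,2-dimethoxyethoxy gives a 3.6-fold higher number from compound 3 to compound 4 (0.56 log units; beyond the scatter), beyond the scatter. Going by these compounds alone, the only earlier single-place step, a 1.1-fold higher number from compound 1 to compound 2 (0.03 log units; within the scatter), lay at a carbonyl carbon and stayed within the scatter, so it said nothing about this chain. The present change swaps hydroxymethyl, which has a hydrogen-bond donor, for the larger dimethoxymethyl, which has none but more hydrogen-bond acceptors, and no measurement shown gives a reason for the step.

This one pair leaves open whether the step follows the loss of the donor, the gain in acceptors or the larger size of the entering group; a 2-methoxyethoxy or a 2-aminoethoxy chain on the rest of compound 3 would help to separate these. Also open, going by these compounds, is whether the same exchange gives a step of similar size when the rest of the molecule is that of compound 1 or compound 2, where the chain is different and the number starts higher.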